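The source may hold more compounds than are shown below. What is called first, only, known or untested is meant among the compounds shown, and "the series" means these compounds.

Three compounds share one core and were measured in an assay for binding affinity to Corticotropin releasing factor receptor (Rattus norvegicus); a lower number here means a stronger inhibitor, a higher number a weaker inhibitor. Compound 1 `CCCC(C)n1c(CC)nc2c(-c3ccc(/C(C)=N\OC)cc3Cl)ccnc21` gives 2.3 nM, compound 2 `CCCC(C)n1c(CC)nc2c(-c3ccc(C(C)(C)O)cc3Cl)ccnc21` gives 24 nM, and compound 3 `CCc1nc2c(-c3ccc(Cl)cc3Cl)ccnc2n1C(C)C1CCC1` gives 1 nM, the lowest of the three numbers; its nearest neighbour is compound 1, its furthest compound 2. For the measured compounds named here, the one step between measured compounds that differ in one place, a 10-fold higher number from compound 1 to compound 2 (1.02 log units; beyond the scatter), concerns the group on the aromatic carbon of the pendant ring, not the substituent on the aromatic nitrogen.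

Compound 4 `CCc1nc2c(-c3ccc(Cl)cc3Cl)ccnc2n1C(CCOC)C1CC1` differs from compound 3 only at that nitrogen: 1-cyclopropyl-3-methoxypropyl in place of 1-cyclobutylethyl on an aromatic nitrogen. Going by the values given here, no measured step touches this position, so the single known step offers no direct guide, and the substituent on the aromatic nitrogen is otherwise varied only between compound 1 and compound 3, which also differ elsewhere. The expectation for the step in this assay is therefore modest, a 2.5-fold higher number from compound 3 to compound 4 (0.40 log units; beyond the scatter), with a slight lean toward a higher number. Compound 4 is expected to give 2.5 nM, in the range 0.8 nM to 8 nM.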

Compound 4, inhibition constant: 1.5 nM
Compound 4: the middle estimate sits 1.7-fold (0.22 log units) above what was measured; measured number inside the range.
By their numbers in this assay, from the lowest: compounds 3, 4 and 1 (each within the scatter of the next, the first and the last beyond it); then compound 2.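

In this assay, for the compounds shown here, the substituent on the aromatic nitrogen is changed on its own for the first time, and a 1.5-fold higher number from compound 3 to compound 4 (0.18 log units; within the scatter) stays within the usual scatter. At this position, 1-cyclopropyl-3-methoxypropyl, which brings more heavy atoms, a three-membered ring and a hydrogen-bond acceptor, takes the place of 1-cyclobutylethyl with no readable change in the number, whereas the change on the pendant ring, a 10-fold higher number from compound 1 to compound 2 (1.02 log units; beyond the scatter), lies beyond it. Nothing measured here gives a reason for this result.

As far as these compounds go, the ring and the methoxy group change together in this one step, so their separate contributions remain open. Also open, from the compounds shown here alone, is how a chain ending in an amine or a carboxylic acid would read at this nitrogen.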